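A few compounds are considered here, and "the series" means these few. Any claim that something is new, unique, unknown or untested is made for them only; others in the source may bear on it.

Three compounds that share one core differ only in the aromatic group attached to the carbon with a double bond to nitrogen. Compound 1 `CN(C)CCn1cnnc1-c1cc(Oc2ccc(NC(=O)N/N=C/c3c[nH]c4ccccc34)cc2F)ccn1` carries an indol-3-yl there; in a functional assay on NCI-H460 cells (Homo sapiens) for cytotoxicity, read by MTT assay, with a stated time of 72 h (a higher number here means a weaker inhibitor, a lower number a stronger inhibitor), compound 1 gives 1630 nM. Compound 2 `CN(C)CCn1cnnc1-c1cc(Oc2ccc(NC(=O)N/N=C/c3c(O)ccc4ccccc34)cc2F)ccn1` carries a 2-hydroxynaphthalen-1-yl, and in this assay compound 2 gives 890 nM. Compound 3 `CN(C)CCn1cnnc1-c1cc(Oc2ccc(NC(=O)N/N=C/c3ccc(O)c(F)c3)cc2F)ccn1` carries a 3-fluoro-4-hydroxyphenyl, and in this assay compound 3 gives 2620 nM, the highest of the three numbers. The step of a 1.6-fold higher number from compound 1 to compound 3 (0.21 log units; within the scatter) stays within the scatter, while the step of a 2.9-fold higher number from compound 2 to compound 3 (0.47 log units; beyond the scatter) goes beyond it.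

Compound 4 `CN(C)CCn1cnnc1-c1cc(Oc2ccc(NC(=O)N/N=C/c3ccc(O)cc3O)cc2F)ccn1` is not yet measured. It differs from compound 3 in one place: 2,4-dihydroxyphenyl in place of 3-fluoro-4-hydroxyphenyl on a carbon with a double bond to nitrogen. Among the compounds with values here, none of the measured steps swaps one hydroxyphenyl for another; the two steps ending at compound 3 only show that its group gives a number no lower than the others. Within the data shown here, with no direct precedent, the expected step of a 1.3-fold lower number from compound 3 to compound 4 (0.12 log units; within the scatter) in this assay is estimated to stay within the scatter. Compound 4 is therefore estimated to give 2000 nM, with a range from 800 nM to 5000 nM.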

Compound 4, half-maximal inhibitory concentration: 11300 nM
Beside the measured number, compound 4's estimate is 5.7-fold (0.75 log units) below it; measured number outside the range, above it.
By their numbers in this assay, from the lowest: compounds 2, 1 and 3 (each within the scatter of the next, the first and the last beyond it); then compound 4.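

Up to this point, the groups on the carbon with a double bond to nitrogen had moved the number in this assay only modestly, the widest step being a 2.9-fold higher number from compound 2 to compound 3 (0.47 log units; beyond the scatter). Compound 4 shows that this place can matter much more: exchanging one substituted phenyl for another gives (a 4.3-fold higher number from compound 3 to compound 4 (0.63 log units; beyond the scatter)), the distance from the indole-bearing compound is larger (a 6.9-fold higher number from compound 1 to compound 4 (0.84 log units; beyond the scatter)), and the distance from the naphthalene-bearing compound is large (a 13-fold higher number from compound 2 to compound 4 (1.10 log units; beyond the scatter)), leaving compound 4 as the weakest of the four. The change is also a small one on paper, as 3-fluoro-4-hydroxyphenyl and 2,4-dihydroxyphenyl both have 8 heavy atoms and one six-membered aromatic ring of carbon only, so ring type and heavy-atom count do not separate them, and no measurement shown here accounts for the higher number.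

Going by these compounds, two things happen in this single step, the fluorine leaving and a second hydroxyl entering, and it remains open which of them goes with the higher number. On these data alone, a plain 4-hydroxyphenyl would bear on that question, and how a 2,4-dimethoxyphenyl or a 4-aminophenyl would read at this place is also open.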